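The compounds below may be only part of what the source reports. "The series", "measured", "known", "first", "only" and "open" are said of these compounds alone.

Measured in a functional assay on MDA-MB-231 cells (Homo sapiens) for antiproliferative activity, read by MTT assay, with a stated time of 72 h; a higher number here means a weaker inhibitor, a lower number a stronger inhibitor:
- compound 1 `CC1=CC[C@H]2[C@H](CC[C@]2(C)O)C(C)(C)[C@@H]1CC[C@H]1[C@]2(C)CC[C@H](OC(=O)c3ccc(C(F)(F)F)cc3)C(C)(C)O[C@H]2CC[C@@]1(C)O` gives 19500 nM in this series
- compound 2 `COc1ccc(C(=O)O[C@H]2CC[C@]3(C)[C@H](CC[C@@](C)(O)[C@H]3CC[C@@H]3C(C)=CC[C@H]4[C@H](CC[C@]4(C)O)C3(C)C)OC2(C)C)cc1` gives 30600 nM in this series

Within the data shown here, compound 2 has a single measured neighbour, and a 1.6-fold higher number from compound 1 to compound 2 (0.20 log units; within the scatter) is the only measured step. Compound 3 `CC1=CC[C@H]2[C@H](CC[C@]2(C)O)C(C)(C)[C@@H]1CC[C@H]1[C@]2(C)CC[C@H](OC(=O)c3ccccc3[N+](=O)[O-])C(C)(C)O[C@H]2CC[C@@]1(C)O` differs from compound 2 by 2-nitrophenyl in place of 4-methoxyphenyl on a carbonyl carbon. Among the measured compounds shown here, the measured step also swaps a group on the aromatic ring, but no measured compound carries 2-nitrophenyl. For the measured compounds named here, with only that small step to go on, no change beyond the scatter is expected. The expected step is a 1.2-fold lower number from compound 2 to compound 3 (0.09 log units; within the scatter) in this estimate. Compound 3 is estimated at 25000 nM (range from 10000 nM to 60000 nM).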

Compound 3, half-maximal inhibitory concentration: 38700 nM
The estimate for compound 3 lay 1.5-fold (0.19 log units) below the measured number; measured number inside the range.
By their numbers in this assay, from the lowest: compounds 1, 2 and 3 (each within the scatter of the next).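

With a 1.3-fold higher number from compound 2 to compound 3 (0.10 log units; within the scatter) and with a 2.0-fold higher number from compound 1 to compound 3 (0.30 log units; within the scatter) in this assay the aryl groups on this carbonyl carbon cannot be told apart. The 2-nitrophenyl ester thus extends the earlier picture to a third aryl group, and its substituent sits at a different ring position from those of the 4-methoxyphenyl and 4-(trifluoromethyl)phenyl esters, yet all steps stay within the scatter. No available data explain this flat result. Still open, going by these compounds, is whether an aliphatic chain, or a phenyl ring carrying an amine or a carboxylic acid, would give a step beyond the scatter at this carbonyl carbon.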